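The compounds below may be only part of what the source reports. "The series", "measured", "known", "first", "only" and "open" are said of these compounds alone.

Three compounds have been measured in an assay on a protein complex for inhibition of integrin alpha-5/beta-1 (Homo sapiens), read by ELISA; on this read-out lower numbers stand for stronger inhibition and higher numbers for weaker inhibition:

compound 1 `COc1ccnc(NC[C@@H]2C[C@@H](OCC(=O)NC[C@H](NC(=O)C3(C)CCCCC3)C(=O)O)CN2C(=O)CC(C)(C)C)c1` gives 0.55 nM
compound 2 `COc1ccnc(NC[C@@H]2C[C@@H](OCC(=O)NC[C@H](NS(=O)(=O)c3c(C)cc(C)cc3C)C(=O)O)CN2C(=O)CC(C)(C)C)c1` gives 0.9 nM
compound 3 `Cc1cc(C)c(S(=O)(=O)N[C@@H](CNC(=O)CO[C@@H]2C[C@@H](CNc3ccccn3)N(C(=O)OCc3ccccc3)C2)C(=O)O)c(C)c1` gives 3.7 nM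

Compound 1 and compound 2 share one core and differ in a single place: (1-methylcyclohexyl)carbonyl in place of (2,4,6-trimethylphenyl)sulfonyl on an amine nitrogen. That change made a 1.6-fold lower number from compound 2 to compound 1 (0.21 log units; within the scatter), so the two numbers cannot be told apart here. Compound 3 carries the same (2,4,6-trimethylphenyl)sulfonyl group as compound 2 but sits on a different core; the difference between the two cores is not broken down here. Compound 3 has the highest number of the three.

Compound 4 `CC1(C(=O)N[C@@H](CNC(=O)CO[C@@H]2C[C@@H](CNc3ccccn3)N(C(=O)OCc3ccccc3)C2)C(=O)O)CCCCC1` has not yet been measured. It arises from compound 3 by the same change as that from compound 2 to compound 1: (1-methylcyclohexyl)carbonyl in place of (2,4,6-trimethylphenyl)sulfonyl on an amine nitrogen, at a place described in the same words. Since that change earlier gave a 1.6-fold lower number from compound 2 to compound 1 (0.21 log units; within the scatter), the step expected here is a 1.5-fold lower number from compound 3 to compound 4 (0.17 log units; within the scatter), which rests on that single measured pair alone. In this assay compound 4 is therefore estimated at 2.5 nM, with a likely range from 1 nM to 6 nM.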

Compound 4, half-maximal inhibitory concentration: 1.7 nM
Compound 4: the middle estimate sits 1.5-fold (0.17 log units) above what was measured, within the range that was stated.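

In this assay, putting (1-methylcyclohexyl)carbonyl in place of (2,4,6-trimethylphenyl)sulfonyl on the amine nitrogen gave a 2.2-fold lower number from compound 3 to compound 4 (0.34 log units; beyond the scatter), and this step can be set beside the one measured on the other core: the same change on two cores in this assay, a 1.6-fold lower number (0.21 log units; within the scatter) from compound 2 to compound 1 and a 2.2-fold lower number (0.34 log units; beyond the scatter) from compound 3 to compound 4, 1.3-fold (0.12 log units) apart, within the scatter of two such steps. The size of the step therefore held across these two cores, with no difference that can be told apart, so the change carried over from one to the other in this pair of cases. Within the data shown here, this does not show that it would carry over to a third core, and since the step on the core of compound 1 lies within the scatter, only the step to compound 4 stands as a real drop on its own.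

The compounds shown leave open how a plain cyclohexylcarbonyl group, without the methyl, or an acetyl group would behave on the same amine nitrogen on either core. They also leave open whether the carboxylic acid could give way to its methyl ester with the number holding up.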